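The source may report more compounds than this note shows. Statements on the series, on what has been measured and on what is new or still open speak of the compounds shown alone.

Three compounds have been measured in an ADME assay on V79 cells (Cricetulus griseus) for cytotoxicity, read by MTT assay, with a stated time of 72 h; a lower number here means a stronger inhibitor, a higher number a weaker inhibitor:

Compound 1 `COc1ccc(Nc2nnnn2-c2ccccc2F)cc1` gives 212000 nM.
Compound 2 `COc1ccc(Nc2nnnn2-c2ccccc2Br)cc1` gives 119000 nM.
Compound 3 `COc1ccc(-n2nnnc2Nc2cccc(Br)c2)cc1` gives 241000 nM.

Compound 1 and compound 2 share one core; the change between them is fluoro in place of bromo on an aromatic carbon, and it gave a 1.8-fold higher number from compound 2 to compound 1 (0.25 log units; within the scatter). Compound 3 has the same atoms as compound 2 joined differently; how the two cores differ is not broken down here. Compound 4 `COc1ccc(-n2nnnc2Nc2cccc(F)c2)cc1` has not yet been measured in this assay. It differs from compound 3 by fluoro in place of bromo on an aromatic carbon. This is the same kind of change as that from compound 2 to compound 1, not the same: in compound 1 the fluoro stands ortho to a large group, in compound 4 meta to a large group. Because a 1.8-fold higher number from compound 2 to compound 1 (0.25 log units; within the scatter) was a small step, the step is expected to be a 1.4-fold higher number from compound 3 to compound 4 (0.14 log units; within the scatter). Compound 4 is therefore expected to give 330000 nM in this assay, estimated between 150000 nM and 700000 nM.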

Compound 4, half-maximal inhibitory concentration: 248000 nM
For compound 4 the middle estimate is 1.3-fold (0.12 log units) above the measured one, within the range that was stated.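

In this assay, fluoro in place of bromo on the second core gave a 1.0-fold higher number from compound 3 to compound 4 (0.01 log units; within the scatter). Set beside the earlier step on the other core, this step shows no difference that can be told from scatter: the same change on two cores in this assay, a 1.8-fold higher number (0.25 log units; within the scatter) from compound 2 to compound 1 and a 1.0-fold higher number (0.01 log units; within the scatter) from compound 3 to compound 4, 1.7-fold (0.24 log units) apart, within the scatter of two such steps. The change therefore carried across these two cores without a detectable shift, but both steps are small, and this does not show that it would carry to any further core.

The compounds shown hold only bromo and fluoro at the changing place. As far as these compounds go, whether an amine or a carboxylic acid there would give a step beyond the scatter in this assay, and whether such a step would carry between the two cores, remains open.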